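Trimming the amide substituent of a PLK2 inhibitor series

This account rests on a few compounds, and the source may have more. Where it says the series, first, only, none or still open, it means among the compounds named here.

Compound 1: `CCCNC(=O)c1ccc2c(ccn2-c2ncc3c(n2)N(c2ccn(C)n2)C(CC)C(=O)N3C)c1`, in an assay for inhibition of serine/threonine-protein kinase PLK2 (Homo sapiens), read by FRET and Z'-LYTE, with a stated time of 1 h (on this read-out higher numbers stand for weaker inhibition and lower numbers for stronger inhibition), compound 1 gives 207 nM.
Compound 2: `CCCCNC(=O)c1ccc2c(ccn2-c2ncc3c(n2)N(c2ccn(C)n2)C(CC)C(=O)N3C)c1`, compound 2 gives 159 nM.
Compound 3: `CCC1C(=O)N(C)c2cnc(-n3ccc4cc(C(=O)NCC(C)C)ccc43)nc2N1c1ccn(C)n1`, compound 3 gives 159 nM.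

Within this set compound 3 stands level with compound 2, the two sharing the lowest number, and the only other gap is small: a 1.3-fold lower number from compound 1 to compound 3 (0.11 log units; within the scatter). All three measured steps concern the alkyl group on the amide nitrogen: a 1.3-fold lower number from compound 1 to compound 2 (0.11 log units; within the scatter), a 1.3-fold lower number from compound 1 to compound 3 (0.11 log units; within the scatter) and no change at the digits printed from compound 2 to compound 3 (within the scatter). Each of them stays inside the scatter, so lengthening or branching that chain has made no visible difference so far.

Compound 4, `CCC1C(=O)N(C)c2cnc(-n3ccc4cc(C(N)=O)ccc43)nc2N1c1ccn(C)n1`, takes a different kind of step: hydrogen in place of isobutyl on an amide-type nitrogen. The measured steps rearranged the chain while keeping an alkyl group on that nitrogen; none of them removed it altogether, so they bear on compound 4 only indirectly. Their flatness suggests the chain is not what drives the number, but a primary carboxamide lies outside what has been tested, and a modest loss cannot be ruled out. Compound 4 is therefore expected to give roughly 400 nM in this assay, within a range of 150 nM to 1200 nM, which corresponds to an expected step of a 2.5-fold higher number from compound 3 to compound 4 (0.40 log units; beyond the scatter).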

Compound 4, half-maximal inhibitory concentration: 384 nM
Compound 4: the middle estimate sits 1.0-fold (0.02 log units) above what was measured; the measured number falls inside the stated range.
By their numbers in this assay, from the lowest: compounds 2, 3, 1 and 4 (each within the scatter of the next, the first and the last beyond it).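

In this assay, within the data shown here, removing the alkyl group from the amide-type nitrogen altogether produces the first changes at this position that rise above the scatter: hydrogen in place of isobutyl gives a 2.4-fold higher number from compound 3 to compound 4 (0.38 log units; beyond the scatter), and hydrogen in place of butyl gives a 2.4-fold higher number from compound 2 to compound 4 (0.38 log units; beyond the scatter). Compound 1 goes against any general rule, since hydrogen in place of propyl gives a 1.9-fold higher number from compound 1 to compound 4 (0.27 log units; within the scatter), so the alkyl group matters measurably only in the comparisons with compound 2 and compound 3, and then only modestly. Nothing available here accounts for this difference between the carbamoyl compound and its alkylated relatives.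

The compounds shown leave open whether the number shifts gradually or abruptly as the chain shortens, a question that methyl or ethyl on the amide-type nitrogen would address. Also open, as far as these compounds go, is how a carboxylic acid or a nitrile in place of the carbamoyl group, or a cyclopropyl group on that nitrogen, would read in this assay on the same shared core.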